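The source may report more compounds than this note shows. Statements on the series, on what has been measured and on what is new or still open speak of the compounds shown alone.

Working notes on the series.

Compound 1 `C=C(C)[C@@H]1CC=C(Cn2cc(COc3cccc(C4NC(=O)NC(C)=C4C(C)=O)c3)nn2)CC1` gives 49800 nM in a functional assay on PC-3 cells (Homo sapiens) for inhibition, read by sulforhodamine B assay, with a stated time of 48 h; on this read-out lower numbers stand for stronger inhibition of growth and higher numbers for weaker inhibition of growth. Compound 2 `C=C(C)[C@@H]1CC=C(Cn2cc(COc3cc(C4NC(=O)NC(C)=C4C(C)=O)ccc3OC)nn2)CC1` returns only a limit, > 100000 nM, in this assay; this is a limit of the assay and not a number. The step of an at least 2.0-fold higher number from compound 1 to compound 2 (0.30 log units; that floor lies within the scatter) is therefore a floor, because of the limit of > 100000 nM in this assay, at which 1 of the 3 values shown sits. The change behind it is methoxy in place of hydrogen on an aromatic carbon.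

Compound 3 `C=C(C)[C@@H]1CC=C(Cn2cc(COc3ccc(C4NC(=O)NC5=C4C(=O)CC(C)(C)C5)cc3)nn2)CC1` gives 24000 nM in this assay, the lowest number of the two measured. How the core of compound 3 differs from the core of compound 1 is not broken down here.

Compound 4 `C=C(C)[C@@H]1CC=C(Cn2cc(COc3ccc(C4NC(=O)NC5=C4C(=O)CC(C)(C)C5)cc3OC)nn2)CC1` carries the change (methoxy in place of hydrogen on an aromatic carbon). This is the same kind of change as from compound 1 to compound 2, but the place differs: meta to a large group rather than para to a large group. Resting on an at least 2.0-fold higher number from compound 1 to compound 2 (0.30 log units; that floor lies within the scatter), the step from compound 3 to compound 4 is expected to be a 2.5-fold higher number from compound 3 to compound 4 (0.40 log units; beyond the scatter). Compound 4 is estimated at 60000 nM, between 25000 nM and 150000 nM.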

Compound 4, concentration for total growth inhibition: > 100000 nM
Compound 4 gave a limit, no number; the forecaster's own chance of this, stated with the estimate: 30%; at least 1.6-fold (0.22 log units) between middle value and limit.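

Compound 4 gives > 100000 nM in this assay and this is a limit of the assay, not a number. The step reads an at least 4.1-fold higher number from compound 3 to compound 4 (0.61 log units; beyond the scatter) and so shows weaker inhibition of growth with methoxy in place of hydrogen on the core of compound 3. How far the size of this change carries from one core to the other is not shown: the same change on two cores in this assay, an at least 2.0-fold higher number (0.30 log units; that floor lies within the scatter) from compound 1 to compound 2 and an at least 4.1-fold higher number (0.61 log units; beyond the scatter) from compound 3 to compound 4; the limit leaves it open whether they differ

Neither methoxy compound gives a number that could fix the size of its step: the limit of > 100000 nM in this assay, at which 2 of the 4 values shown sit.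

The compounds shown leave open whether a group smaller than methoxy, such as fluorine or hydroxyl, on this aromatic carbon would keep the growth inhibition of compound 3. They also leave open how the change would read at other places on the ring.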